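The compounds below may be only part of what the source reports. "The series", "measured", "known", "first", "only" and "open" are said of these compounds alone.

In a functional assay on NCI-H460 cells (Homo sapiens) for cytotoxicity (on this read-out higher numbers stand for weaker inhibition and lower numbers for stronger inhibition), compound 1 `CS(=O)(=O)c1ccc2nc(NC(=O)CCCCC(=O)NO)sc2c1` gives only a limit, > 30 ug/mL. Compound 2 `O=C(CCCCC(=O)Nc1nc2ccc([N+](=O)[O-])cc2s1)NO` also gives only a limit, > 30 ug/mL. Compound 2 thus stands at the limit of > 30 ug/mL in this assay, at which 2 of the 2 values shown sit, and no number places it more exactly. Compound 3 `CCOc1ccc2nc(NC(=O)CCCCC(=O)NO)sc2c1` carries ethoxy in place of nitro on an aromatic carbon, (ethoxy in place of nitro on an aromatic carbon). The change lies on a six-membered aromatic ring of carbon only, part of a fused or bridged system of two rings. Within the data shown here, the one measured step that bears on it is a step that the two limits leave unreadable from compound 1 to compound 2, with nitro in place of methylsulfonyl on an aromatic carbon. Both ends of that step are limits, and it offers no size to carry over. Neither compound 1 nor compound 2 has yet given a number in this assay, so the expectation stays close to that limit, with no firm direction. The expected step is a number no higher from compound 2 to compound 3 (the limit leaves the size open), which is an estimate resting on very little. Compound 3 is expected at 30 ug/mL, with an estimated range from 10 ug/mL to 60 ug/mL.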

Compound 3, half-maximal inhibitory concentration: 7.96 ug/mL
For compound 3 the middle estimate is 3.8-fold (0.58 log units) above the measured one; measured number below the stated range.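

With compound 3, this position gives the first true number in this assay, so the series is no longer held at the limit of the read-out: the limit of > 30 ug/mL in this assay, at which 2 of the 3 values shown sit.

Replacing the nitro group with ethoxy brings an at least 3.7-fold lower number from compound 2 to compound 3 (0.57 log units; beyond the scatter), and replacing the methylsulfonyl group with ethoxy brings an at least 3.7-fold lower number from compound 1 to compound 3 (0.57 log units; beyond the scatter); both steps start from limits, so each gives only a smallest size and the true difference may be larger. The group on this aromatic carbon can therefore move the result beyond the scatter with the rest of the molecule unchanged, although the step between compound 1 and compound 2 cannot be read, as both of its ends are limits.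

The compounds shown leave open whether the oxygen attached to the ring or the two carbons of the ethoxy group account for the difference, a question that methoxy, a longer alkoxy chain or an ethyl group at the same carbon would help to answer. They also give no cause for the step, and they leave open how an amine or a carboxylic acid at this position would compare with ethoxy.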